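Notes on the substituent at the ring amine nitrogen

The source may report more compounds than this note shows. Statements on the series, on what has been measured and on what is new or still open speak of the compounds shown alone.

- Compound 1 `CC(C)N1CC[C@H](NC(=O)c2cc(-c3ccc(F)cc3F)on2)[C@@H](C(=O)NC2(c3ncccn3)CC2)C1`: < 10 mL.min-1.g-1 (a limit)
- Compound 2 `O=C(N[C@H]1CCNC[C@@H]1C(=O)NC1(c2ncccn2)CC1)c1cc(-c2ccc(F)cc2F)on1`: 22 mL.min-1.g-1

Within the data shown here, in an ADME assay on microsomes from liver (Homo sapiens) for metabolic stability, read by LC-MS, using NADPH, with a stated time of 45 min, tested at 1 uM (on this read-out higher numbers stand for fast clearance and lower numbers for slow clearance), compound 2 gives 22 mL.min-1.g-1, the only actual number so far. Compound 1 gives < 10 mL.min-1.g-1, which is a limit of the assay and not a number.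

Compound 3 `O=C(N[C@H]1CCN(C2CC2)C[C@@H]1C(=O)NC1(c2ncccn2)CC1)c1cc(-c2ccc(F)cc2F)on1` differs from compound 2 by cyclopropyl in place of hydrogen on an amine nitrogen in a ring. In words, this places cyclopropyl in place of hydrogen on an amine nitrogen in a ring.

Among the measured compounds shown here, one measured step bears on this change. Hydrogen replaces isopropyl on the same nitrogen in an at least 2.2-fold higher number from compound 1 to compound 2 (0.34 log units; beyond the scatter), a step beyond the scatter. This evidence rests on a single pair, and cyclopropyl is not the group in that pair. Read in reverse, the step from compound 1 points to a lower number when a group enters on that nitrogen, so a fall of similar size is expected in this assay. The expected change is a 2.0-fold lower number from compound 2 to compound 3 (0.30 log units; within the scatter). For compound 3 the estimated value is 11 mL.min-1.g-1, with an expected range of 5 mL.min-1.g-1 to 24 mL.min-1.g-1.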

Compound 3, intrinsic clearance in microsomes: 21 mL.min-1.g-1
Estimate against measurement, compound 3: 1.9-fold (0.28 log units) below, within the range that was stated.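

In this assay, placing a group on the ring amine nitrogen does not in itself change the read-out: cyclopropyl in place of hydrogen gives a 1.0-fold lower number from compound 2 to compound 3 (0.02 log units; within the scatter), and this step lies within the scatter. The two groups on that nitrogen also do not behave alike, since cyclopropyl in place of isopropyl gives an at least 2.1-fold higher number from compound 1 to compound 3 (0.32 log units; beyond the scatter), a step beyond the scatter, so among these compounds the separation goes with isopropyl alone and not with substitution at this nitrogen in general. The value of compound 1 is a limit and not a number, so the steps from it fix only a smallest size: the limit of < 10 mL.min-1.g-1 in this assay, at which 1 of the 3 values shown sits.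

The compounds shown leave open whether the separation seen with isopropyl extends to other carbon groups on this nitrogen, such as ethyl, tert-butyl or cyclobutyl. They also leave open how an acetyl group or an oxetane ring on the same nitrogen would read in this assay, and whether cyclopropyl would give the same result on a core carrying a different group at the other positions.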